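This account rests on a few compounds, and the source may have more. Where it says the series, first, only, none or still open, it means among the compounds named here.

Series notes. Compound 1 `O=C(Nc1cccc(-n2cc(-c3ccncc3)c(-c3ccc(Cl)c(O)c3)n2)c1)Nc1cccc(C(F)(F)F)c1` carries a free hydroxyl on the aryl ring attached to the shared core; in a functional assay on OVCAR-5 cells (Homo sapiens) for inhibition, read by sulforhodamine B assay, with a stated time of 48 h (a lower number here means a stronger inhibitor of growth, a higher number a weaker inhibitor of growth), compound 1 gives 13700 nM. Compound 3 `COc1cc(-c2nn(-c3cccc(NC(=O)Nc4cccc(C(F)(F)F)c4)c3)cc2-c2ccncc2)ccc1Cl` has the methyl ether instead, and in this assay compound 3 gives 1270 nM, the step of an 11-fold lower number from compound 1 to compound 3 (1.03 log units; beyond the scatter) being the one large effect seen so far. Compound 2 `COc1cc(-c2nn(-c3cccc(NC(=O)Nc4cc(C(F)(F)F)cc(C(F)(F)F)c4)c3)cc2-c2ccncc2)ccc1Cl` adds a second trifluoromethyl to the urea aryl ring and in this assay compound 2 gives 937 nM; the step of a 1.4-fold higher number from compound 2 to compound 3 (0.13 log units; within the scatter) is flat. Compound 3 therefore sits second of the three numbers, close to compound 2 and far from compound 1.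

Compound 4 `COc1cc(-c2nn(-c3cccc(NC(=O)c4ccccc4)c3)cc2-c2ccncc2)ccc1Cl` differs from compound 3 by phenyl in place of (3-(trifluoromethyl)phenyl)amino on a carbonyl carbon, turning the urea into a benzamide. For the measured compounds named here, no measured step covers this change. Going by the values given here, the only related evidence is the flat step a 1.4-fold higher number from compound 2 to compound 3 (0.13 log units; within the scatter), which shows that trimming trifluoromethyl from that ring costs little; the loss of the urea nitrogen is untested. A modest weakening is expected, a 2.0-fold higher number from compound 3 to compound 4 (0.29 log units; within the scatter), and compound 4 is estimated at 2500 nM, within 800 nM to 8000 nM.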

Compound 4, concentration for 50% growth inhibition: 15000 nM
For compound 4 the middle estimate is 6.0-fold (0.78 log units) below the measured one, outside the stated range (above it).
By their numbers in this assay, from the lowest: compounds 2 and 3 (each within the scatter of the next); then compounds 1 and 4 (each within the scatter of the next).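

Putting phenyl in place of (3-(trifluoromethyl)phenyl)amino on the carbonyl carbon gives a 12-fold higher number from compound 3 to compound 4 (1.07 log units; beyond the scatter) in this assay. This position therefore responds strongly to a change, whereas removing one trifluoromethyl from the urea aryl ring gave only a 1.4-fold higher number from compound 2 to compound 3 (0.13 log units; within the scatter). The amino nitrogen and the remaining trifluoromethyl leave together in this step, so the size of the step cannot be assigned to either one, and no data here bear on why the number moves so far.

Open, going by these compounds, is how much of the step follows the amino nitrogen alone, a question that phenylamino on the same carbonyl carbon would address. Also open, on these data alone, is how this position responds to other groups on that carbon, such as benzylamino or a longer alkyl chain.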